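Replacing isopropylsulfanyl with dimethylamino on a carbonyl carbon

The source may hold more compounds than are shown below. What is called first, only, known or untested is meant among the compounds shown, and "the series" means these compounds.

Compounds measured in a physicochemical assay for lipophilicity (a lower number here means a more polar compound, a higher number a more lipophilic compound), so far
Compound 1 `C=CCOC(=O)/C=C(C)/C=C/CC(C)CCCC(C)(C)OC` gives 5.53
Compound 2 `COC(C)(C)CCCC(C)C/C=C/C(C)=C/C(=O)SC(C)C` gives 7.19

Of the two, compound 2 stands highest in this assay at 7.19 so far. Compound 3 `COC(C)(C)CCCC(C)C/C=C/C(C)=C/C(=O)N(C)C` has yet to be measured. It differs from compound 2 in one place: dimethylamino in place of isopropylsulfanyl on a carbonyl carbon. Within the data shown here, only one measured step bears on this, and it is large: a number 1.66 log units higher from compound 1 to compound 2 (beyond the scatter) with isopropylsulfanyl in place of allyloxy on a carbonyl carbon. Among the measured compounds shown here, since isopropylsulfanyl now leaves, a large step down is expected, although no measured step involves dimethylamino. The expected step is a number 2.59 log units lower from compound 2 to compound 3 (beyond the scatter) on this estimate. For compound 3 the estimated value is 4.6 with an expected range from 3.7 to 5.5 in this estimate.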

Compound 3, partition coefficient: 3.74
The estimate for compound 3 lay 0.86 log units above the measured number, within the range that was stated.
By their numbers in this assay, from the lowest: compound 3; then compound 1; then compound 2.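

In this assay, dimethylamino on the carbonyl carbon gives a number 3.45 log units lower from compound 2 to compound 3 (beyond the scatter) and, in place of allyloxy, gives a number 1.79 log units lower from compound 1 to compound 3 (beyond the scatter) at the same place. The position therefore moves the number downward as well as upward, and the three groups now stand in a clear order: dimethylamino lowest, allyloxy in the middle and isopropylsulfanyl highest. Changing the group on this carbonyl carbon alone spans the whole measured range.

Going by these compounds, whether a carboxylic acid or a methylamino group here would fall below dimethylamino remains open. Nothing available accounts for the size of these steps.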